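This account rests on a few compounds, and the source may have more. Where it says the series, first, only, none or still open, it means among the compounds named here.

Measured so far:
compound 1 `CN(C)c1nonc1/C(=N/O)Nc1ccc(F)c(Br)c1` — in an assay on HeLa cells for inhibition of Indoleamine 2,3-dioxygenase 1 (Homo sapiens), with a stated time of 48 h (a higher number here means a weaker inhibitor, a lower number a stronger inhibitor), compound 1 gives > 5000 nM, which is a limit of the assay and not a number.
compound 2 `O/N=C(\Nc1ccc(F)c(Br)c1)c1nonc1NCc1ccccc1` — in this assay compound 2 gives 280 nM.

Within the data shown here, compound 2 holds the only numerical value shown; the other value shown sits at a limit (the limit of > 5000 nM in this assay, at which 1 of the 2 values shown sits). Among the measured compounds shown here, the single measured step, an at least 17-fold lower number from compound 1 to compound 2 (1.25 log units; beyond the scatter), shows that the group on the amino nitrogen of the shared core matters greatly.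

Compound 3 `CS(=O)(=O)NCCNc1nonc1/C(=N/O)Nc1ccc(F)c(Br)c1` differs from compound 2 by (methanesulfonamido)methyl in place of phenyl on a saturated chain carbon bound to a nitrogen on an aromatic ring. No measured step covers an exchange of this kind on the saturated chain carbon; the one step shown only says that replacing dimethylamino by benzylamino made the number fall sharply. Removing the phenyl again is therefore expected to cost potency, though the chain and its amino nitrogen are kept. The estimate for compound 3 is 1500 nM, between 300 nM and 8000 nM, which means an expected step of a 5.4-fold higher number from compound 2 to compound 3 (0.73 log units; beyond the scatter).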

Compound 3, half-maximal inhibitory concentration: 16 nM
Estimate against measurement, compound 3: 94-fold (1.97 log units) above, and the stated range ends above it.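

In this assay the exchange of phenyl for (methanesulfonamido)methyl on a saturated chain carbon bound to a nitrogen on an aromatic ring gives an 18-fold lower number from compound 2 to compound 3 (1.24 log units; beyond the scatter) and shows that an aromatic ring is not required at this place for a low number. The exchange on the aromatic carbon, with (2-(methanesulfonamido)ethyl)amino in place of dimethylamino, gives an at least 310-fold lower number from compound 1 to compound 3 (2.49 log units; beyond the scatter) and extends the range this position spans in the series. That step has an open end, as compound 1 stands at a limit and not at a number: the limit of > 5000 nM in this assay, at which 1 of the 3 values shown sits.

Whether the methanesulfonamide itself is needed stays open, as a carboxylic acid, a primary amine or a longer chain at this place does not appear among the compounds shown. The bromo and fluoro substituents are shared by all three compounds, so their part cannot be read.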